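The source may report more compounds than this note shows. Statements on the series, on what has been measured and on what is new or still open speak of the compounds shown alone.

Measured compounds:
- compound 1 `NC(=O)Cc1cc(=O)oc2cc(OCc3cccc(Cl)c3)ccc12`: 30 nM
- compound 2 `O=C(Cc1cc(=O)oc2cc(OCc3cccc(Cl)c3)ccc12)NCc1ccccc1`: 5000 nM

Both compounds share one core and differ only at the amide nitrogen. In an assay for inhibition of Amine oxidase [flavin-containing] B (Rattus norvegicus) (a higher number here means a weaker inhibitor, a lower number a stronger inhibitor), compound 1 gives 30 nM, while compound 2 gives 5000 nM, the higher of the two numbers; the step of a 170-fold higher number from compound 1 to compound 2 (2.22 log units; beyond the scatter) is large and well beyond the scatter, so the added benzyl on the amide-type nitrogen weakened inhibition markedly.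

Compound 3 `NCc1cc(=O)oc2cc(OCc3cccc(Cl)c3)ccc12` has not yet been measured. Compared with compound 2, the change is amino in place of benzylcarbamoyl on a saturated chain carbon bound to an aromatic carbon. This removes the whole benzylcarbamoyl group, leaving a primary amine on that chain carbon.

For the measured compounds named here, the only measured step that bears on this change is the one from compound 1 to compound 2, which shows that the benzyl on the nitrogen costs a great deal. Taking it away again should recover most or all of that loss, and compound 3 is expected to give a much lower number than compound 2 in this assay, a step of about a 330-fold lower number from compound 2 to compound 3 (2.52 log units; beyond the scatter). The estimate for compound 3 in this assay is 15 nM, with a range from 3 nM to 80 nM.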

Compound 3, half-maximal inhibitory concentration: 15 nM
Estimate against measurement, compound 3: no gap at the digits printed; the measured number falls inside the stated range.
By their numbers in this assay, from the lowest: compounds 3 and 1 (each within the scatter of the next); then compound 2.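

In this assay, the result is a 330-fold lower number from compound 2 to compound 3 (2.52 log units; beyond the scatter), which shows that the core of compound 3 needs no benzylcarbamoyl group on this saturated chain carbon to reach the low end of the numbers seen so far. The earlier compounds had shown only that the benzyl on the amide-type nitrogen is costly, whereas this change removes the carbonyl as well, and amino in place of carbamoyl gives a 2.0-fold lower number from compound 1 to compound 3 (0.30 log units; within the scatter), so these two small groups cannot be told apart in this assay. Nothing measured here explains why the two small groups behave alike or why the benzylcarbamoyl group gives so much higher a number.

As far as these compounds go, it remains open whether other small groups on this chain carbon, such as a hydroxyl group, a carboxylic acid or a methylamino group, would also keep the number low. From the compounds shown here alone, it is also open whether a longer chain carrying the amine, or a benzyl placed on the amine of compound 3, would carry a penalty like the one seen in the earlier step (a 170-fold higher number from compound 1 to compound 2 (2.22 log units; beyond the scatter)).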